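Swapping the amine: from compound 1 to compound 4

The source may hold more compounds than are shown below. What is called first, only, known or untested is meant among the compounds shown, and "the series" means these compounds.

Measured in an ADME assay on HFF cells (Homo sapiens) for cytotoxicity, with a stated time of 8 days; a higher number here means that more compound is tolerated, a lower number that less compound is tolerated:
- compound 1 `CN(C)c1nc(N)nc2c1ncn2/C=C1/CC1(CO)CO`: > 300000 nM
- compound 2 `Nc1nc(NCc2ccccc2)c2ncn(/C=C3/CC3(CO)CO)c2n1`: > 300000 nM
- compound 3 `Nc1nc2c(ncn2/C=C2/CC2(CO)CO)c(=O)[nH]1`: > 300000 nM

Each of these entries is a limit of the assay and not a number. Compound 1 therefore has only a limit to its name, and the same holds across the set: the limit of > 300000 nM in this assay, at which 3 of the 3 values shown sit.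

Compound 4 `Nc1nc(NC2CCCC2)c2ncn(/C=C3/CC3(CO)CO)c2n1` carries cyclopentylamino in place of dimethylamino on an aromatic carbon. Among the measured compounds shown here, the one measured step that bears on this also replaces the dimethylamino group: a step that the two limits leave unreadable from compound 1 to compound 2. Its size cannot be read, but it gives no sign of a drop in tolerance. The expected step in this assay is a number no higher from compound 1 to compound 4 (the limit leaves the size open), which means no change beyond the scatter in either direction. For compound 4 the estimated value is 300000 nM, with an expected range from 100000 nM to 600000 nM.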

Compound 4, half-maximal cytotoxic concentration: > 300000 nM
Compound 4: only a limit was reported; the forecaster's own chance of this, stated with the estimate: 80%; the middle value lies on the limit itself.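

The steps from compound 1 and from compound 2 to compound 4 cannot be read, because all these entries are limits: the limit of > 300000 nM in this assay, at which 4 of the 4 values shown sit.

Going by these compounds, whether any of these amine swaps changes tolerance in this assay stays open.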